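Compound 2 to compound 4: a swap on the carbonyl carbon

A few compounds are considered here, and "the series" means these few. Any claim that something is new, unique, unknown or untested is made for them only; others in the source may bear on it.

In an ADME assay on L02 cells (Homo sapiens) for antiproliferative activity, read by MTT assay, with a stated time of 48 h (a lower number here means a stronger inhibitor, a higher number a weaker inhibitor), compound 2 `CCn1c(C(=O)NCC#N)ccc1C(CC)(CC)c1ccc(OCCC(O)(CC)CC)c(C)c1` gives only a limit, > 50000 nM. That places it at the limit of > 50000 nM in this assay, at which 1 of the 3 values shown sits.

In the same assay, compound 1 `CCN(CC)CCNC(=O)c1ccc(C(CC)(CC)c2ccc(OCCC(O)(CC)CC)c(C)c2)n1CC` gives 2290 nM and compound 3 `CCn1c(C(=O)N(CCC#N)CCC#N)ccc1C(CC)(CC)c1ccc(OCCC(O)(CC)CC)c(C)c1` gives 37800 nM. Compound 4 `C#CC(C)OC(=O)c1ccc(C(CC)(CC)c2ccc(OCCC(O)(CC)CC)c(C)c2)n1CC` is not yet measured. It differs from compound 2 by (1-methylprop-2-yn-1-yl)oxy in place of (cyanomethyl)amino on a carbonyl carbon, with (1-methylprop-2-yn-1-yl)oxy in place of (cyanomethyl)amino on a carbonyl carbon.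

Within the data shown here, three measured steps bear on this change. Two are large: an at least 21-fold higher number from compound 1 to compound 2 (1.33 log units; beyond the scatter) and a 17-fold higher number from compound 1 to compound 3 (1.22 log units; beyond the scatter). Among the measured compounds shown here, both start from compound 1, the only measured compound with a diethylamino group, and compound 4 has none. The third step is the closer guide, as both its compounds lack that group: an at least 1.3-fold lower number from compound 2 to compound 3 (0.12 log units; that floor lies within the scatter).

No step beyond the scatter is therefore expected, in either direction. The expected step is an at least 1.2-fold lower number from compound 2 to compound 4 (0.09 log units; that floor lies within the scatter). In this assay compound 4 is estimated at 40000 nM, with an expected range of 15000 nM to 80000 nM.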

Compound 4, half-maximal inhibitory concentration: > 50000 nM
Compound 4 ended at the assay's limit; the forecaster's own chance of this, stated with the estimate: 40%; middle value at least 1.2-fold (0.09 log units) from the limit.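

Compound 4 is a limit in this assay, and it shares that limit with compound 2: the limit of > 50000 nM in this assay, at which 2 of the 4 values shown sit.

The step between these two limits cannot be read, while an at least 1.3-fold higher number from compound 3 to compound 4 (0.12 log units; that floor lies within the scatter) leaves compound 4 not separated from the nitrile amide with the larger group on the carbonyl carbon. With an at least 21-fold higher number from compound 1 to compound 4 (1.33 log units; beyond the scatter) as a further large step, the much lower number among the four compounds stays with (2-(diethylamino)ethyl)amino alone, and this now holds against an oxygen-linked group on the carbonyl carbon as well as against the nitrogen-linked nitrile groups.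

The compounds shown do not separate the diethylamino end from the ethyl chain that carries it. From the compounds shown here alone, how a primary amine or a piperidine at the end of that chain, or a longer chain before the diethylamino group, would read in this assay remains open.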